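The source may hold more compounds than are shown below. What is called first, only, known or untested is meant among the compounds shown, and "the series" means these compounds.

The series rests on a shared core carrying an aniline whose fluorine pattern varies. Compound 1, `O=C1C(Nc2ccc(F)c(F)c2)=CC(=O)c2ncccc21`, is measured in a functional assay on the whole organism (aorta) with Rattus norvegicus as the target (on this read-out lower numbers stand for smaller maximal responses and higher numbers for larger maximal responses), and gives 92%. Compound 2, `O=C1C(Nc2ccc(F)cc2F)=CC(=O)c2ncccc21`, gives in this assay a value of 94%. The gap between the two numbers lies within the usual scatter of such measurements, so compound 2 and compound 1 cannot be told apart on this read-out; both reach nearly the full response of the control. Within the data shown here, no step between measured compounds is recorded for this pair, and what the two values show is simply that the two fluorine arrangements behave alike here.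

Compound 3, `O=C1C(Nc2ccc(F)c(F)c2F)=CC(=O)c2ncccc21`, carries one change relative to compound 2: fluoro in place of hydrogen on an aromatic carbon. Among the measured compounds shown here, with two values this close and no recorded step to guide the direction, no movement beyond the scatter is expected. The step from compound 2 to compound 3 is expected to be a number 2 percentage points lower from compound 2 to compound 3 (within the scatter). Compound 3 is therefore estimated to give 92% in this assay, with a range from 80% to 100%.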

Compound 3, largest response reached (Emax), in percent of the reference or control that the assay uses: 72%
Compound 3: the middle estimate sits 20 percentage points above what was measured, outside the stated range (below it).
By their numbers in this assay, from the lowest: compound 3; then compounds 1 and 2 (each within the scatter of the next).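

In this assay, fluoro in place of hydrogen on this aromatic carbon, ortho to two fluoro groups in compound 3, gives a number 22 percentage points lower from compound 2 to compound 3 (beyond the scatter) and also a number 20 percentage points lower from compound 1 to compound 3 (beyond the scatter) as the step read from the other parent. Among these compounds, this is the first change that moves the maximal response beyond the scatter, whereas the two earlier fluorine arrangements could not be told apart, so the aniline ring does not tolerate every fluorine pattern equally on this read-out. No measurement shown here accounts for the drop, and the reason for it stays unknown.

The compounds shown leave open whether the lower response belongs to this particular carbon or to the presence of one more fluoro group anywhere on the ring, since compound 3 is the only compound carrying it. They also leave open how a different group at this place, such as a chlorine atom, a methoxy group or an amine, would compare with hydrogen and fluoro in this assay and whether any of them would restore the full response.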